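Working notes on a paw edema series: compound 3 to compound 4

This account rests on a few compounds, and the source may have more. Where it says the series, first, only, none or still open, it means among the compounds named here.

Measured compounds:
compound 1 `COc1ccc(N/C=N/C2=C(C#N)C3C(N4CCCC4)CCCCN3C(=O)N2c2ccccc2)cc1` — 50.2%
compound 2 `N#CC1=C(/N=C/c2ccccc2)N(c2ccccc2)C(=O)N2CCCCC(N3CCCC3)C12` — 84%
compound 3 `CCOC(=O)C(=O)NC1=C(C#N)C2C(N3CCCC3)CCCCN2C(=O)N1c1ccccc1` — 91.5%

In a functional assay on the whole organism (strain albino) for inhibition, with Rattus norvegicus as the target, read by paw edema, with stated times of 1 h and 3 h, at a dose of 20 mmol/kg by the intraperitoneal route (a higher number here means a stronger effect of the compound at the dose given, a lower number a weaker effect), compound 3 gives 91.5%, the highest of the three numbers. Its nearest neighbour is compound 2 with 84%; the step of a number 7.5 percentage points higher from compound 2 to compound 3 (within the scatter) lies within the scatter, so no order between these two can be claimed. Against compound 1, which gives 50.2%, the step of a number 41.3 percentage points higher from compound 1 to compound 3 (beyond the scatter) is beyond the scatter.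

Compound 4 `N#CC1=C(NC(=O)c2ccccc2O)N(c2ccccc2)C(=O)N2CCCCC(N3CCCC3)C12` is next. Its change from compound 3 is 2-hydroxyphenyl in place of ethoxycarbonyl on a carbonyl carbon. The step that bears on it most is a number 7.5 percentage points higher from compound 2 to compound 3 (within the scatter), where an aryl-bearing group and the ester-bearing group at the same place gave numbers within the scatter of one another; the large step of a number 33.8 percentage points higher from compound 1 to compound 2 (beyond the scatter) concerns a different exchange and is a weaker guide. Compound 4 keeps the carbonyl amide and brings in an aromatic ring, which on the pattern of compound 2 and compound 3 suggests no step beyond the scatter.

Compound 4 is therefore expected to give about 85%, with a range of 68% to 96%. The estimated step of a number 6.5 percentage points lower from compound 3 to compound 4 (within the scatter) is expected to stay within the scatter.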

Compound 4, a percentage reported as inhibition, in the whole organism at one dose (the size of the read-out at that dose, not a potency): 65.4%
Compound 4: the middle estimate sits 19.6 percentage points above what was measured, and the stated range ends above it.
By their numbers in this assay, from the lowest: compound 1; then compound 4; then compounds 2 and 3 (each within the scatter of the next).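

In this assay the step of a number 26.1 percentage points lower from compound 3 to compound 4 (beyond the scatter) shows that this carbonyl carbon does not accept 2-hydroxyphenyl in place of ethoxycarbonyl without a change beyond the scatter. The steps of a number 18.6 percentage points lower from compound 2 to compound 4 (beyond the scatter) and a number 15.2 percentage points higher from compound 1 to compound 4 (beyond the scatter) place compound 4 apart from both other compounds, so an aromatic ring in this part of the molecule does not by itself fix the number, as compound 1, compound 2 and compound 4 all carry one there and all differ beyond the scatter from compound 4. No measurement shown here accounts for these steps.

From the compounds shown here alone, it remains open whether the lower number goes with the ring or with its hydroxyl, which plain phenyl or 2-methoxyphenyl on the same carbonyl carbon would separate. A carboxylic acid in place of the ethyl ester would test how much of the number of compound 3 depends on ethoxycarbonyl.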